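A Styryl Group in Place of 2-Chlorophenyl

A few compounds are considered here, and "the series" means these few. Any claim that something is new, unique, unknown or untested is made for them only; others in the source may bear on it.

Measured so far:
compound 1 `Cc1cc(O)c(C2=NN(c3ccc(S(N)(=O)=O)cc3)C(c3ccccc3O)C2)cc1Cl` — 40700 nM
compound 2 `Cc1cc(O)c(C2=NN(c3ccc(S(N)(=O)=O)cc3)C(c3ccccc3Cl)C2)cc1Cl` — 2660 nM

In a functional assay on UO-31 cells (Homo sapiens) for antiproliferative activity, with a stated time of 48 h (on this read-out lower numbers stand for stronger inhibition of growth and higher numbers for weaker inhibition of growth), compound 1 gives 40700 nM, while compound 2 gives 2660 nM. Among the compounds with values here, compound 2 thus holds the lowest of the two numbers, and the only measured step, a 15-fold lower number from compound 1 to compound 2 (1.18 log units; beyond the scatter), separates it from compound 1.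

Compound 3 `Cc1cc(O)c(C2=NN(c3ccc(S(N)(=O)=O)cc3)C(/C=C/c3ccccc3)C2)cc1Cl` is not yet measured. It differs from compound 2 by 2-phenylethenyl in place of 2-chlorophenyl on a saturated ring carbon. Within the data shown here, no measured step bears directly on this change: the step from compound 1 to compound 2 concerns a swap of substituents on an aromatic carbon, whereas here the whole 2-chlorophenyl group is replaced by 2-phenylethenyl at the same saturated ring carbon. That single step shows only that this position can shift the number strongly, in either sense. With no closer guide, compound 3 is expected to stay near compound 2 because its starting point is 2660 nM, and the step of a 1.9-fold higher number from compound 2 to compound 3 (0.27 log units; within the scatter) is estimated to be modest. The estimate for compound 3 in this assay is 5000 nM, within 1200 nM to 25000 nM.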

Compound 3, concentration for 50% growth inhibition: 15200 nM
Compound 3: the middle estimate sits 3.0-fold (0.48 log units) below what was measured, and the stated range covers the measured number.
By their numbers in this assay, from the lowest: compound 2; then compound 3; then compound 1.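

In this assay, putting 2-phenylethenyl in place of 2-chlorophenyl on the saturated ring carbon gives a 5.7-fold higher number from compound 2 to compound 3 (0.76 log units; beyond the scatter), so the number at this carbon responds not only to a swap on the attached phenyl ring but also to replacing the whole group. The same new group gives a 2.7-fold lower number from compound 1 to compound 3 (0.43 log units; beyond the scatter), which places 2-phenylethenyl between 2-chlorophenyl and 2-hydroxyphenyl, with both steps beyond the scatter, and so the three groups form a graded order at this one carbon rather than a simple split between a good and a poor group. Nothing available explains why the number moves in either step.

The compounds shown leave open whether the difference between compound 2 and compound 3 lies in the loss of the chlorine or in the ethenyl link, which a 2-(2-chlorophenyl)ethenyl group would help to separate. As far as these compounds go, it also remains open what the double bond itself contributes, a question that a saturated 2-phenylethyl chain at the same carbon would address, and where a plain phenyl group would fall in this order.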